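Replacing the nitrile of compound 3 with an oxadiazole

The compounds below may be only part of what the source reports. "The series", "measured", "known", "first", "only" and "open" are said of these compounds alone.

In an ADME assay on Huh-7 cells (Homo sapiens) for cytotoxicity, with a stated time of 72 h (on this read-out higher numbers stand for lower toxicity in this test and lower numbers for higher toxicity in this test), compound 3 (`CC(C)(C)[C@H]1C(O)=C(C2=NS(=O)(=O)c3c(OCC#N)cccc32)C(=O)N1Cc1ccc(F)c(Cl)c1`) stands at > 33000 nM as a limit and not a number. Compound 2 (`CC(C)(C)[C@H]1C(O)=C(C2=NS(=O)(=O)c3c(OCC(N)=O)cccc32)C(=O)N1Cc1ccc(F)c(Cl)c1`) likewise gives > 33000 nM as a limit. Going by the values given here, every compound measured so far sits at the same limit (the limit of > 33000 nM in this assay, at which 3 of the 3 values shown sit) and none can be ranked. Compound 4 (`CC(C)(C)[C@H]1C(O)=C(C2=NS(=O)(=O)c3c(OCc4ncon4)cccc32)C(=O)N1Cc1ccc(F)c(Cl)c1`) differs from compound 3 by one exchange (1,2,4-oxadiazol-3-yl in place of cyano on a saturated chain carbon bound to an oxygen on an aromatic ring) with 1,2,4-oxadiazol-3-yl in place of cyano. Among the compounds with values here, the only measured step (a step that the two limits leave unreadable from compound 2 to compound 3) has no readable size. Compound 1 (`CC(C)[C@H]1C(O)=C(C2=NS(=O)(=O)c3c(OCc4ncon4)cccc32)C(=O)N1Cc1ccccc1`) also carries 1,2,4-oxadiazol-3-yl and gives > 33000 nM as a limit. No change beyond the scatter is therefore expected, and the estimated step is a number no higher from compound 3 to compound 4 (the limit leaves the size open) in this assay for now. Compound 4 is estimated at 33000 nM with an expected range from 15000 nM to 50000 nM in this test.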

Compound 4, half-maximal cytotoxic concentration: > 33000 nM
Compound 4 was reported as a limit; the forecaster's own chance of this, stated with the estimate: 85%; the middle value lies on the limit itself.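

In this assay compound 4 gives > 33000 nM, a limit and not a number. The steps to compound 4 from compound 2 and compound 3 cannot be read: the limit of > 33000 nM in this assay, at which 4 of the 4 values shown sit. The compounds shown leave open whether 1,2,4-oxadiazol-3-yl, cyano and carbamoyl differ at all in this test.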